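Swapping the Sulfur-Linked Group on a Shared Core

The compounds below may be only part of what the source reports. "The series", "measured", "known", "first", "only" and "open" are said of these compounds alone.

Compound 1 `N#Cc1c(N)nc(SCC(=O)NCO)c(C#N)c1-c1ccc(OCC2CC2)cc1` gives 8% in an assay on CHO cells for displacement of a labelled ligand from adenosine receptor A3 (Homo sapiens), read by scintillation counting, with a stated time of 120 min, tested at 1 uM; on this read-out higher numbers stand for more inhibition at the one concentration tested (going by the name of the read-out) and lower numbers for less inhibition.
Compound 2 `COC(=O)c1cccc(CSc2nc(N)c(C#N)c(-c3ccc(OCC4CC4)cc3)c2C#N)c1` gives 4% in this assay.
Compound 3 `N#Cc1c(N)nc(SCC2=NCCN2)c(C#N)c1-c1ccc(OCC2CC2)cc1` gives 6% in this assay.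

These three compounds share one core and differ only in the group sitting on a saturated chain carbon bound to a sulfur. On the numbers shown, compound 3 stands second highest of the three; the nearest number is a number 2 percentage points lower from compound 1 to compound 3 (within the scatter) and the furthest is a number 2 percentage points higher from compound 2 to compound 3 (within the scatter), so all three values lie within the scatter of one another.

Compound 4 `COC(=O)CSc1nc(N)c(C#N)c(-c2ccc(OCC3CC3)cc2)c1C#N` has not yet been measured. It differs from compound 3 in one place: a group of 4 heavy atoms (2 carbon, 2 oxygen; no ring) in place of a group of 5 heavy atoms (3 carbon, 2 nitrogen; one five-membered non-aromatic ring with 2 hetero atoms), on a saturated chain carbon bound to a sulfur.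

Every measured step changes this same group, and each stayed within the scatter: a number 4 percentage points lower from compound 1 to compound 2 (within the scatter), a number 2 percentage points lower from compound 1 to compound 3 (within the scatter) and a number 2 percentage points higher from compound 2 to compound 3 (within the scatter). Nothing here suggests that changing this group moves the number in this assay beyond the scatter, in either direction. Compound 4 is therefore expected to give about 6%, with a range from 0% to 16%. That estimate corresponds to no change at the digits printed from compound 3 to compound 4 (within the scatter).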

Compound 4, a percentage reported as inhibition, at one concentration (the size of the read-out at that concentration, not a potency): 1%
For compound 4 the middle estimate is 5 percentage points above the measured one; low and high end bracket the measured number.
By their numbers in this assay, from the lowest: compounds 4, 2, 3 and 1 (each within the scatter of the next).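

In this assay, methoxycarbonyl on a saturated chain carbon bound to a sulfur joins the other groups shown there in staying within the scatter: a number 5 percentage points lower from compound 3 to compound 4 (within the scatter), and a number 3 percentage points lower from compound 2 to compound 4 (within the scatter). The second of these steps takes away the aromatic ring of 3-(methoxycarbonyl)phenyl, while a number 7 percentage points lower from compound 1 to compound 4 (within the scatter), a step that puts methoxy in place of (hydroxymethyl)amino on a carbonyl carbon, so neither change separates its pair of compounds on this read-out. No available evidence bears on why these numbers lie so close together.

As far as these compounds go, whether a primary amine, a carboxylic acid or a longer chain on this saturated chain carbon would give a number beyond the scatter remains open. Every step shown stays in this one part of the molecule, so the effect of changes elsewhere on the shared core is also open.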